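A few compounds are considered here, and "the series" means these few. Any claim that something is new, unique, unknown or untested is made for them only; others in the source may bear on it.

A small series of sulfonyl compounds sharing one core has been tested in a functional assay on HepG2 cells (Homo sapiens) for inhibition, read by sulforhodamine B assay, with a stated time of 74 h; a lower number here means a stronger inhibitor, a higher number a weaker inhibitor. Compound 1 `CS(=O)(=O)N1C(=O)COC12C=CC(=O)C=C2`, with a methyl on the sulfonyl sulfur, gives > 10000 nM, which is a limit of the assay. Compound 2 `O=C1C=CC2(C=C1)OCC(=O)N2S(=O)(=O)c1ccccc1`, with a phenyl there, gives > 10000 nM, again a limit. Compound 3 `O=C1C=CC2(C=C1)OCC(=O)N2S(=O)(=O)c1cccs1`, with a thiophen-2-yl, gives > 10000 nM, also a limit. All three compounds therefore sit at the limit of > 10000 nM in this assay, at which 3 of the 3 values shown sit, and no number is known for compound 3.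

Compound 4 `O=C1C=CC2(C=C1)OCC(=O)N2S(=O)(=O)c1ccc(Br)s1` differs from compound 3 by bromo in place of hydrogen on an aromatic carbon, which turns thiophen-2-yl into 5-bromothiophen-2-yl. The measured steps bearing on this change are those at the same sulfonyl sulfur: a step that the two limits leave unreadable from compound 1 to compound 2, a step that the two limits leave unreadable from compound 1 to compound 3 and a step that the two limits leave unreadable from compound 2 to compound 3. None of them has a readable size, and none adds a bromo, so they give no measured size to carry over. The three limits offer no ground for expecting a step in either direction in this assay.

The expected step is a number no higher from compound 3 to compound 4 (the limit leaves the size open), an estimate set against a limit. For compound 4 the estimated value is 10000 nM, with an expected range from 3000 nM to 30000 nM.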

Compound 4, half-maximal inhibitory concentration: 240 nM
Compound 4: middle estimate off by 42-fold (1.62 log units), on the high side; measured number outside the range, below it.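

In this assay, going by these compounds alone, bromo in place of hydrogen on an aromatic carbon, next to the ring sulfur, gives an at least 41-fold lower number from compound 3 to compound 4 (1.61 log units; beyond the scatter), the first step with a readable size, and that size is only a bound, as compound 3 holds a limit and no number. The earlier steps shown here among compound 1, compound 2 and compound 3 cannot be read, so methyl, phenyl and thiophen-2-yl on the sulfonyl sulfur gave no sign that this substituent could change the result at all: the limit of > 10000 nM in this assay, at which 3 of the 4 values shown sit. Set against the other two compounds, 5-bromothiophen-2-yl gives an at least 41-fold lower number from compound 2 to compound 4 (1.61 log units; beyond the scatter) and an at least 41-fold lower number from compound 1 to compound 4 (1.61 log units; beyond the scatter), and with compound 3 at a limit, the thiophen-2-yl alone does not account for these steps.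

The compounds shown hold a single halogen at a single place, so they leave open whether chloro, iodo, methyl or methoxy on that same carbon would act as bromo does. They also leave open whether a bromo on the phenyl of compound 2 would bring a step of this kind.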